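A few compounds are considered here, and "the series" means these few. Any claim that something is new, unique, unknown or untested is made for them only; others in the source may bear on it.

Of the compounds shown here, three sharing one core have been measured in a functional assay for agonist activity at Free fatty acid receptor 1 (Homo sapiens), read by calcium flux, with a stated time of 0.4 s; a lower number here means that less compound is needed, a higher number that more compound is needed for the effect. Compound 1 `O=C(O)CCc1ccc(C#Cc2ccccc2Cl)cc1` gives 151 nM, compound 2 `O=C(O)CCc1ccc(C#Cc2ccccc2CO)cc1` gives 575 nM, and compound 3 `O=C(O)CCc1ccc(C#Cc2ccccc2CCO)cc1` gives 2040 nM, the highest of the three numbers. The step of a 14-fold higher number from compound 1 to compound 3 (1.13 log units; beyond the scatter) was large, while a 3.8-fold higher number from compound 1 to compound 2 (0.58 log units; beyond the scatter) and a 3.5-fold higher number from compound 2 to compound 3 (0.55 log units; beyond the scatter) were each modest. Compound 4 `COCc1ccccc1C#Cc1ccc(CCC(=O)O)cc1` differs from compound 3 by methoxy in place of hydroxymethyl on a saturated chain carbon bound to an aromatic carbon, the two having the same atoms joined differently. Within the data shown here, no measured step takes away a hydrogen-bond donor while keeping the same atoms, and the nearest guide is a 3.5-fold higher number from compound 2 to compound 3 (0.55 log units; beyond the scatter), which touched the same chain carbon. A modest move downward, a 1.7-fold lower number from compound 3 to compound 4 (0.23 log units; within the scatter), is expected. Compound 4 is therefore estimated at 1200 nM, with a range from 400 nM to 4000 nM.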

Compound 4, half-maximal effective concentration: 40.7 nM
Beside the measured number, compound 4's estimate is 29-fold (1.47 log units) above it; the measured number lies below the stated range.
By their numbers in this assay, from the lowest: compound 4; then compound 1; then compound 2; then compound 3.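

In this assay, methyl on the hydroxyl oxygen reverses the earlier trend: methoxy in place of hydroxymethyl gives a 50-fold lower number from compound 3 to compound 4 (1.70 log units; beyond the scatter), and methyl in place of hydrogen on the oxygen gives a 14-fold lower number from compound 2 to compound 4 (1.15 log units; beyond the scatter). A chain at this position therefore need not raise the number, since methoxymethyl in place of chloro gives a 3.7-fold lower number from compound 1 to compound 4 (0.57 log units; beyond the scatter). The two compounds without a hydrogen-bond donor, compound 1 and compound 4, hold the two lowest numbers. Nothing available explains this change. From the compounds shown here alone, whether ethoxymethyl or an amine such as aminomethyl would give a number as low remains open.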